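The source may report more compounds than this note shows. Statements on the series, on what has been measured and on what is new or still open speak of the compounds shown alone.

The series shares one core. Compound 1, `CCCCCc1nc(C(F)(F)F)ccc1CNC(=O)C(C)c1ccc(NS(C)(=O)=O)c(F)c1`, gives 1 nM in an assay on CHO cells for antagonist activity at transient receptor potential cation channel subfamily V member 1 (Homo sapiens), read by FLIPR and calcium flux; on this read-out lower numbers stand for stronger inhibition and higher numbers for weaker inhibition. Compound 2, `CCC1CCC(c2nc(C(F)(F)F)ccc2CNC(=O)C(C)c2ccc(NS(C)(=O)=O)c(F)c2)CC1`, gives 0.3 nM in this assay, and compound 3, `CC(C(=O)NCc1ccc(C(F)(F)F)nc1C1CCC(C)(C)CC1)c1ccc(NS(C)(=O)=O)c(F)c1`, gives 0.4 nM. On these numbers compound 3 stands second highest of the three; its nearest neighbour is compound 2, whose number lies within the scatter of its own, and its furthest is compound 1. Compound 4, `CC(C(=O)NCc1ccc(C(F)(F)F)nc1C1CC2CCC1C2)c1ccc(NS(C)(=O)=O)c(F)c1`, differs from compound 3 in one place: a group of 7 heavy atoms (7 carbon; 2 five-membered non-aromatic rings of carbon only) in place of a group of 8 heavy atoms (8 carbon; one six-membered non-aromatic ring of carbon only), on an aromatic carbon. Going by the values given here, two measured steps bear on exchanging pentyl for a non-aromatic ring of carbon only: a 3.3-fold lower number from compound 1 to compound 2 (0.52 log units; beyond the scatter) and a 2.5-fold lower number from compound 1 to compound 3 (0.40 log units; beyond the scatter), both modest. The exchange of one such ring for another, a 1.3-fold higher number from compound 2 to compound 3 (0.12 log units; within the scatter), stays within the scatter. The change to compound 4 again exchanges one non-aromatic ring of carbon only for another, so the step of a 1.3-fold higher number from compound 3 to compound 4 (0.10 log units; within the scatter) is expected to stay within the scatter. Compound 4 is therefore estimated at 0.5 nM, with a range from 0.15 nM to 1.5 nM.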

Compound 4, inhibition constant: 1.5 nM
Compound 4: middle estimate off by 3.0-fold (0.48 log units), on the low side; the range from low to high includes it.
By their numbers in this assay, from the lowest: compounds 2 and 3 (each within the scatter of the next); then compounds 1 and 4 (each within the scatter of the next).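

Unlike the exchange between the two cyclohexyl groups, replacing either of them with the group of 2 five-membered non-aromatic rings is not neutral in this assay: a 3.8-fold higher number from compound 3 to compound 4 (0.57 log units; beyond the scatter) and a 5.0-fold higher number from compound 2 to compound 4 (0.70 log units; beyond the scatter) both lie beyond the scatter, so at this position, next to the ring nitrogen, non-aromatic rings of carbon only are not interchangeable. The lower numbers seen when a cyclohexyl group takes the place of pentyl do not carry over to this group, as a 1.5-fold higher number from compound 1 to compound 4 (0.18 log units; within the scatter) stays within the scatter. Nothing available here accounts for these differences.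

From the compounds shown here alone, whether a cyclopentyl, a phenyl or a morpholine at this position would match compound 2 and compound 3 remains open. Going by these compounds, all four compounds share the rest of the structure, so whether these steps hold on another core is also open.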